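Compound 2 to compound 3: an exchange of side group

A few compounds are considered here, and "the series" means these few. Any claim that something is new, unique, unknown or untested is made for them only; others in the source may bear on it.

Compound 1 `COC(=O)C1=C(CN2CCC(O)C2)NC(c2nccs2)=NC1(C)c1ccc(F)cc1`: 83 mL/min/kg
Compound 2 `COC(=O)C1=C(Cn2ccnc2)NC(c2nccs2)=NC1(C)c1ccc(F)cc1`: 69 mL/min/kg

In an ADME assay on microsomes from liver (Mus musculus) for metabolic stability, read by LC-MS, using NADPH, with stated times of 10 min and 30 min, tested at 1 uM (a higher number here means faster removal of the compound, a lower number slower removal), compound 2 gives 69 mL/min/kg and lies within the scatter of compound 1 (83 mL/min/kg), so these two numbers cannot be ranked.

Compound 3 `COC(=O)C1=C(CN2CC(OC)C2)NC(c2nccs2)=NC1(C)c1ccc(F)cc1` has not yet been measured. It carries 3-methoxyazetidin-1-yl in place of 1H-imidazol-1-yl on a saturated chain carbon bound to a double-bonded ring carbon.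

For the measured compounds named here, the one measured step at this place put 1H-imidazol-1-yl in place of 3-hydroxypyrrolidin-1-yl. That step (a 1.2-fold lower number from compound 1 to compound 2 (0.08 log units; within the scatter)) stayed within the scatter, so a step of similar size is expected here. The estimated step in this assay (a 1.1-fold higher number from compound 2 to compound 3 (0.05 log units; within the scatter)) is accordingly none beyond the scatter. Going by the values given here, this rests on a single step, and no measured compound carries 3-methoxyazetidin-1-yl, so the range is kept wide. The expected value for compound 3 is 78 mL/min/kg (estimated range 48 mL/min/kg to 125 mL/min/kg).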

Compound 3, clearance: 88 mL/min/kg
For compound 3 the middle estimate is 1.1-fold (0.05 log units) below the measured one, and the stated range covers the measured number.
By their numbers in this assay, from the lowest: compounds 2, 1 and 3 (each within the scatter of the next).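

In this assay, the exchange of the aromatic 1H-imidazol-1-yl for the non-aromatic 3-methoxyazetidin-1-yl, on a saturated chain carbon bound to a double-bonded ring carbon, gives a 1.3-fold higher number from compound 2 to compound 3 (0.11 log units; within the scatter), so even this change of ring type and ring size does not separate the two compounds. The comparison of the two non-aromatic groups, 3-methoxyazetidin-1-yl and 3-hydroxypyrrolidin-1-yl, gives a 1.1-fold higher number from compound 1 to compound 3 (0.03 log units; within the scatter), which means that all three groups seen at this position now lie within the scatter of one another, and the read-out does not distinguish among them. Nothing available explains this lack of separation or links it to any feature of the groups.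

As far as these compounds go, whether a simple open-chain amine such as dimethylamino, a carboxylic acid or a longer chain in this place would give a step beyond the scatter remains open. The three compounds also share the rest of their structure, so they leave unanswered whether a change elsewhere on the shared core, such as replacing the methyl ester with an amide, would move the number in this assay.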